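This account rests on a few compounds, and the source may have more. Where it says the series, first, only, none or still open, it means among the compounds named here.

Measured so far, in an ADME assay on HEK293 cells (Homo sapiens) for cytotoxicity, read by CCK-8 assay and cell counting, with a stated time of 2 days; a higher number here means a weaker inhibitor, a lower number a stronger inhibitor:

Compound 1, `Oc1ccc(-c2cc(-c3ccc(Cl)cc3)nc(-c3ccsc3)c2)cc1`, gives 4860 nM.
Compound 2, `Oc1ccc(-c2cc(-c3ccccc3)nc(-c3ccc(Cl)cc3)c2)cc1`, gives 4810 nM.
Compound 3, `Oc1cccc(-c2cc(-c3ccccc3)nc(-c3ccccc3Cl)c2)c1`, gives 1760 nM.

Compounds 1 and 2 share a core and differ in one place only: thiophen-3-yl in place of phenyl on an aromatic carbon. That swap made a 1.0-fold higher number from compound 2 to compound 1 (0.00 log units; within the scatter), so in these two compounds the exchange of a phenyl for a thiophen-3-yl left the read-out where it was. Compound 3 is built from the same atoms as compound 2 joined differently; the difference between the two cores is not broken down here. Compound 3 stands lowest of the three values, and its gap to compound 2 is beyond the scatter.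

Compound 4, `Oc1cccc(-c2cc(-c3ccsc3)nc(-c3ccccc3Cl)c2)c1`, has not yet been measured. It is related to compound 3 by the same kind of change: thiophen-3-yl in place of phenyl on an aromatic carbon. The surroundings are not identical, though: in compound 2 the place is meta to a 4-chlorophenyl group and meta to a 4-hydroxyphenyl group, while in compound 3 it is meta to a 2-chlorophenyl group and meta to a 3-hydroxyphenyl group.

Among the measured compounds shown here, the expectation for compound 4 rests on the only measured example of this swap, where compound 1 and compound 2 showed a 1.0-fold higher number from compound 2 to compound 1 (0.00 log units; within the scatter). The step from compound 3 to compound 4 is therefore expected to be small, about a 1.0-fold higher number from compound 3 to compound 4 (0.01 log units; within the scatter). Compound 4 is estimated at 1800 nM, with a likely range from 900 nM to 3600 nM.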

Compound 4, half-maximal inhibitory concentration: 2720 nM
Beside the measured number, compound 4's estimate is 1.5-fold (0.18 log units) below it; the measured number falls inside the stated range.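

In this assay, the second example of thiophen-3-yl in place of phenyl gave a 1.5-fold higher number from compound 3 to compound 4 (0.19 log units; within the scatter), so on this core too the change stays within the usual scatter of repeated measurements. Set beside the first example, the two steps do not differ by more than that scatter: the same change on two cores in this assay, a 1.0-fold higher number (0.00 log units; within the scatter) from compound 2 to compound 1 and a 1.5-fold higher number (0.19 log units; within the scatter) from compound 3 to compound 4, 1.5-fold (0.18 log units) apart, within the scatter of two such steps. Among the compounds shown here, on these two cores, which carry their chlorophenyl and hydroxyphenyl groups differently, the swap therefore carried over as a change too small to read, but this rests on only two pairs of compounds and does not show that the two rings can be exchanged freely on every core of the series or in any other test.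

The compounds shown leave open whether a different group at this place, such as a furan, a pyridine, an amine or a longer alkyl chain, would shift the number beyond the scatter, given that neither thiophen-3-yl nor phenyl stands apart here. They also leave open what happens when the hydroxyl group is exchanged for a methoxy group or a carboxylic acid while the thiophen-3-yl stays in place.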